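Swapping the ureido group on a sugar core for a carboxy group

This account rests on a few compounds, and the source may have more. Where it says the series, first, only, none or still open, it means among the compounds named here.

Measured compounds:
compound 1, `NC[C@H]1O[C@H](CO)[C@@H](O)[C@H](O)[C@H]1O`, 31600000 nM
compound 2, `NC(=O)CS[C@H]1O[C@H](CO)[C@@H](O)[C@H](O)[C@H]1O`, 20000000 nM
compound 3, `NC(=O)N[C@H]1O[C@H](CO)[C@@H](O)[C@H](O)[C@H]1O`, 126000 nM

The three measured compounds share the same sugar-shaped core and differ only in the group attached to the saturated ring carbon next to the ring oxygen. In an assay on isolated protein (Sus scrofa) for inhibition of glycogen phosphorylase, brain form (Homo sapiens) (on this read-out lower numbers stand for stronger inhibition and higher numbers for weaker inhibition), compound 1 gives 31600000 nM, compound 2 gives 20000000 nM, and compound 3 gives 126000 nM. Compound 3 is the strongest inhibitor of the three: the step of a 250-fold lower number from compound 1 to compound 3 (2.40 log units; beyond the scatter) and the step of a 160-fold lower number from compound 2 to compound 3 (2.20 log units; beyond the scatter) both lie well beyond the scatter, whereas the step of a 1.6-fold lower number from compound 1 to compound 2 (0.20 log units; within the scatter) does not.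

Compound 4, `O=C(O)[C@H]1O[C@H](CO)[C@@H](O)[C@H](O)[C@H]1O`, is not yet measured. Its change from compound 3 is carboxy in place of ureido on a saturated ring carbon. Among the compounds with values here, both earlier steps at this position were large, which shows that this position is sensitive to what group sits there; only the ureido group has given a strong number so far. Within the data shown here, a carboxy group is a different kind of group from either of the weaker ones, so no measured step maps directly onto this change. The expectation is therefore cautious: compound 4 is estimated to lose much of the gain seen for compound 3, with the step of a 40-fold higher number from compound 3 to compound 4 (1.60 log units; beyond the scatter) expected in this assay. Compound 4 is estimated at 5000000 nM, within a range from 800000 nM to 30000000 nM.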

Compound 4, inhibition constant: 15800000 nM
Compound 4: middle estimate off by 3.2-fold (0.50 log units), on the low side; the measured number falls inside the stated range.
By their numbers in this assay, from the lowest: compound 3; then compounds 4, 2 and 1 (each within the scatter of the next).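

In this assay, the step of a 130-fold higher number from compound 3 to compound 4 (2.10 log units; beyond the scatter) shows that a carboxy group on this saturated ring carbon does not keep what the ureido group gave. Compound 4 instead joins the two weak compounds, with a 1.3-fold lower number from compound 2 to compound 4 (0.10 log units; within the scatter) and a 2.0-fold lower number from compound 1 to compound 4 (0.30 log units; within the scatter), so carboxy, (carbamoylmethyl)sulfanyl and aminomethyl give numbers that cannot be told apart here, and only ureido stands clear of them. Since carboxy and ureido each hold a carbonyl directly on this ring carbon, a carbonyl there is not enough on its own for the stronger number in these compounds.

No measurement given here explains why ureido alone stands apart from the other three groups. Also open, as far as these compounds go, is whether an acetamido group or a methylureido group on this saturated ring carbon would stay close to compound 3 at 126000 nM or fall back with the others.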